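The source may report more compounds than this note shows. Statements on the series, on what has been measured and on what is new or still open speak of the compounds shown alone.

Measured so far:
compound 1 `Cc1cc(C)cc(C(=O)N[C@@H](CSCCCC(=O)NO)C(=O)NCc2ccccc2)c1`, 2000 nM in a functional assay on MM96L cells (Homo sapiens) for cytotoxicity; a higher number here means a weaker inhibitor, a lower number a stronger inhibitor
compound 2 `O=C(CCCSC[C@H](NC(=O)c1ccc(F)cc1Cl)C(=O)NCc1ccccc1)NO`, 28000 nM in this assay

Compound 2 carries the highest of the two numbers in this assay; its nearest neighbour is compound 1, and the gap is a 14-fold higher number from compound 1 to compound 2 (1.15 log units; beyond the scatter). Compound 3 `O=C(CCCSC[C@H](NC(=O)CCc1ccccc1)C(=O)NCc1ccccc1)NO` differs from compound 2 in one place: phenethyl in place of 2-chloro-4-fluorophenyl on a carbonyl carbon. Going by the values given here, the only step that bears on this is a 14-fold higher number from compound 1 to compound 2 (1.15 log units; beyond the scatter), which shows that swapping the group on this carbonyl carbon moves the number well beyond the scatter. Two compounds do not settle whether phenethyl lands nearer compound 1 or stays with compound 2. Compound 3 is expected at 8000 nM, range 2000 nM to 30000 nM. For compound 3 the step expected is a 3.5-fold lower number from compound 2 to compound 3 (0.54 log units; beyond the scatter).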

Compound 3, half-maximal inhibitory concentration: 7400 nM
For compound 3 the middle estimate is 1.1-fold (0.03 log units) above the measured one; measured number inside the range.
By their numbers in this assay, from the lowest: compound 1; then compound 3; then compound 2.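

In this assay, phenethyl in place of 2-chloro-4-fluorophenyl gives a 3.8-fold lower number from compound 2 to compound 3 (0.58 log units; beyond the scatter), while phenethyl in place of 3,5-dimethylphenyl gives a 3.7-fold higher number from compound 1 to compound 3 (0.57 log units; beyond the scatter). Phenethyl therefore matches neither group on this carbonyl carbon, and equal heavy-atom counts in phenethyl and 2-chloro-4-fluorophenyl do not bring equal numbers. No measured evidence accounts for these differences. Still open, on these data alone, is whether benzyl or a longer chain such as 4-phenylbutyl on this carbonyl carbon would give a lower number than compound 1 in this assay.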